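Chain shortening on the alkyne side chain of the shared core

A few compounds are considered here, and "the series" means these few. Any claim that something is new, unique, unknown or untested is made for them only; others in the source may bear on it.

Compound 1 `CCCCc1cc2cn(COCCO)c(=O)nc2o1` carries a butyl chain on the shared core. In a functional assay on HEL cells (Homo sapiens), read by microscopy (on this read-out lower numbers stand for higher toxicity in this test and higher numbers for lower toxicity in this test), compound 1 reports only a limit, > 400000 nM. Compound 2 `CCCCCCCCC#Cc1cc2cn(COCCO)c(=O)nc2o1` bears a longer alkyne-linked chain. In this assay compound 2 likewise stands at a limit, >= 20000 nM, so no number is fixed for it. Compound 3 `CCCCC#Cc1cc2cn(COCCO)c(=O)nc2o1` differs from compound 2 by hydrogen in place of butyl on a saturated chain carbon, four bonds along the chain from a triple-bonded carbon. Within the data shown here, no measured step in the set bears on this change, so nothing beyond the scatter is claimed for this assay; the expected step that the limit leaves unreadable from compound 2 to compound 3 is set near the limit. For compound 3 the estimate is 100000 nM, expected within 20000 nM to 400000 nM.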

Compound 3, minimum cytotoxic concentration: > 100000 nM
Compound 3 was reported as a limit; the forecaster's own chance of this, stated with the estimate: 70%; the middle value sits exactly at the limit.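

Among these compounds, compound 1, compound 2 and compound 3 are all reported only as limits, so no step among them can be read. The compounds shown leave open whether any of these side chains gives a fixed value in this assay.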